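The source may hold more compounds than are shown below. What is called first, only, known or untested is meant among the compounds shown, and "the series" means these compounds.

Measured so far:
Compound 1 `Cc1c(C(=O)O)c(-c2cccc(N3CCN(c4ccc(NS(=O)(=O)c5ccc(N[C@H](CCN6CC(O)C6)CSc6ccccc6)c(S(=O)(=O)C(F)(F)F)c5)cc4)CC3)c2)c(-c2ccc(Cl)cc2)n1C`: 7.7 nM
Compound 2 `Cc1c(C(=O)NCCCN2CCN(C)CC2)c(-c2cccc(N3CCN(c4ccc(NS(=O)(=O)c5cccc(S(=O)(=O)C6CC6)c5)cc4)CC3)c2)c(-c2ccc(Cl)cc2)n1C`: 844 nM

Both numbers come from an assay for inhibition of Apoptosis regulator Bcl-2 (Homo sapiens), read by fluorescence polarization, with a stated time of 2 h; on this read-out lower numbers stand for stronger inhibition and higher numbers for weaker inhibition. Of the two, compound 2 has the higher one, so it is the weaker inhibitor; compound 1 lies far lower, a gap well beyond the usual scatter. Both share a large common core, and they differ in several places at once, so no single change can be tied to that gap.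

Compound 3 `COc1cccc(S(=O)(=O)Nc2ccc(N3CCN(c4cccc(-c5c(C(=O)NCCCN6CCN(C)CC6)c(C)n(C)c5-c5ccc(Cl)cc5)c4)CC3)cc2)c1` has not yet been tested in this assay. It differs from compound 2 in one place only: methoxy in place of cyclopropylsulfonyl on an aromatic carbon. A group with a three-membered ring and two oxygen atoms is thus traded for a much smaller one, on the ring bearing the sulfonamide.

Among the compounds with values here, with no measured pair showing such a swap, the expectation rests on compound 2 alone, whose value of 844 nM sets the starting point. Compound 3 is expected to give about 1500 nM, most likely between 400 nM and 6000 nM. This estimate means a step of a 1.8-fold higher number from compound 2 to compound 3 (0.25 log units; within the scatter), expected to be modest, leaning toward weaker inhibition but possibly within the scatter.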

Compound 3, half-maximal inhibitory concentration: 802 nM
Compound 3: the middle estimate sits 1.9-fold (0.27 log units) above what was measured; the measured number falls inside the stated range.
By their numbers in this assay, from the lowest: compound 1; then compounds 3 and 2 (each within the scatter of the next).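

In this assay, putting methoxy in place of cyclopropylsulfonyl on this aromatic carbon gives a 1.1-fold lower number from compound 2 to compound 3 (0.02 log units; within the scatter) and so leaves compounds 2 and 3 indistinguishable. For this pair, a group of 6 heavy atoms with a three-membered ring and 2 hydrogen-bond acceptors can thus give way to one of 2 heavy atoms with no ring and 1 hydrogen-bond acceptor, with no measurable effect on the read-out, though this is a single swap on a single shared core. Nothing measured here explains why the two numbers match.

From the compounds shown here alone, whether a different group on this carbon, such as an amine or a nitrile, would also leave the number unchanged remains open, as does whether the same swap would do so in the setting of compound 1. Compound 1, at 7.7 nM, differs from compounds 2 and 3 in several places, so the compounds shown do not reveal which of those differences accounts for its much lower number.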